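This account rests on a few compounds, and the source may have more. Where it says the series, first, only, none or still open, it means among the compounds named here.

In a functional assay on the whole organism for positive allosteric modulation, with Mus musculus as the target (a higher number here means that more compound is needed for the effect, a lower number that less compound is needed), compound 1 (`CCC(=O)N(c1ccc(Cl)c(Cl)c1)C1CCCC1O`) gives 0.4 mg/kg and holds the lowest of the three numbers. Compound 3 (`CCC(=O)N(c1ccc(C)c(Cl)c1)C1CCCC1N(C)C`) comes nearest at 1 mg/kg and compound 2 (`CCC(=O)N(c1ccccc1C)C1CCCC1N(C)C`) lies furthest at 7 mg/kg with both gaps beyond the scatter. Compound 4 (`CCCN(CCC)C1CCCC1N(C(=O)CC)c1ccc(Cl)c(Cl)c1`) keeps the rest of compound 1 but carries dipropylamino in place of hydroxy on a saturated ring carbon. Among the compounds with values here, no measured step isolates this change. The closest guide is compound 3 at 1 mg/kg since it also has an amino group on that ring carbon, though its other ring substituents differ. A rise in the required dose beyond the scatter is therefore expected, and the estimated move is a 5.0-fold higher number from compound 1 to compound 4 (0.70 log units; beyond the scatter) in this reading. For compound 4 the estimated dose is 2 mg/kg with an expected range from 0.5 mg/kg to 10 mg/kg before measurement.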

Compound 4, dose for half-maximal effect: 2 mg/kg
The estimate for compound 4 equals the measured number at the digits printed, within the range that was stated.
By their numbers in this assay, from the lowest: compound 1; then compounds 3 and 4 (each within the scatter of the next); then compound 2.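

In this assay, within the data shown here, the swap of dipropylamino in place of hydroxy on a saturated ring carbon gives the first reading that isolates this position: a 5.0-fold higher number from compound 1 to compound 4 (0.70 log units; beyond the scatter). The larger group, with no hydrogen-bond donor, raises the number, yet compound 4 still gives a measured dose of 2 mg/kg. No measurement shown here accounts for this step. From the compounds shown here alone, what remains open is whether the rise follows the loss of hydroxy or the arrival of dipropylamino. A methoxy or an unsubstituted amino group on that carbon, on the core of compound 1, would separate the two.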